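Replacing a sulfanyl bridge in a potent orexin ligand

The source may hold more compounds than are shown below. What is called first, only, known or untested is meant among the compounds shown, and "the series" means these compounds.

Measured so far:
compound 1 `Cc1ccc2[nH]c(SCC(=O)N3CCC[C@H]3C(=O)Nc3ccccc3-n3cccc3)nc2c1` — 0.2 nM
compound 2 `Cc1ccc2c(c1)nc(SCC(=O)N1CCC[C@H]1C(=O)Nc1ccccc1-n1cccc1)n2C` — 0.09 nM

In an assay on CHO cells for displacement of a labelled ligand from Orexin receptor type 2 (Homo sapiens) (a lower number here means a stronger inhibitor, a higher number a weaker inhibitor), compound 1 gives the higher of the two numbers. Within the data shown here, the single measured step, a 2.2-fold lower number from compound 1 to compound 2 (0.35 log units; beyond the scatter), touches only the ring nitrogen and says nothing about the bridge. Compound 3 `O=C(Nc1ccccc1-n1cccc1)[C@@H]1CCCN1C(=O)CCc1nc2ccccc2[nH]1` changes that bridge: (1H-benzimidazol-2-yl)methyl in place of (5-methyl-1H-benzimidazol-2-yl)sulfanyl on a saturated chain carbon bound to a carbonyl carbon. Among the measured compounds shown here, no measured step bears on this change, so the expectation rests on compound 1 alone and is uncertain. A modest weakening is expected, a 3.0-fold higher number from compound 1 to compound 3 (0.48 log units; beyond the scatter), so compound 3 is estimated at 0.6 nM, within 0.15 nM to 3 nM.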

Compound 3, inhibition constant: 11 nM
Beside the measured number, compound 3's estimate is 18-fold (1.26 log units) below it, and the stated range ends below it.
By their numbers in this assay, from the lowest: compound 2; then compound 1; then compound 3.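

In this assay, placing (1H-benzimidazol-2-yl)methyl where (5-methyl-1H-benzimidazol-2-yl)sulfanyl stood gives a 55-fold higher number from compound 1 to compound 3 (1.74 log units; beyond the scatter), so this part of the molecule matters far more than the earlier ring nitrogen step could suggest. The change removes the sulfur and the 5-methyl group together, so this one step cannot divide the loss between them. Nothing measured here explains the loss. Still open, going by these compounds, is whether (5-methyl-1H-benzimidazol-2-yl)methyl alone would restore the strength of compound 1. Also open, on these data alone, is how a bridge holding an ether oxygen or an amine nitrogen would compare.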